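The source may report more compounds than this note shows. Statements on the series, on what has been measured and on what is new or still open speak of the compounds shown alone.

Measured compounds in a functional assay on CHO cells for agonist activity at Free fatty acid receptor 1 (Homo sapiens), read by FLIPR and calcium flux, tested at 1 uM; a higher number here means that more compound is needed for the effect, a lower number that less compound is needed:
- compound 1 `Cc1ccc(C)c(OCc2nnc(C(=O)Nc3ccc(CCC(=O)O)cc3)s2)c1` — 1530 nM
- compound 2 `COc1ccc(OCc2nnc(C(=O)Nc3ccc(CCC(=O)O)cc3)s2)cc1` — 2430 nM
- compound 3 `Cc1ccccc1OCc1nnc(C(=O)Nc2ccc(CCC(=O)O)cc2)s1` — 1520 nM

All three share the same core and differ only in the aryl ether on the saturated carbon. The steps among them are small: a 1.6-fold higher number from compound 1 to compound 2 (0.20 log units; within the scatter), a 1.0-fold lower number from compound 1 to compound 3 (0.00 log units; within the scatter), a 1.6-fold lower number from compound 2 to compound 3 (0.20 log units; within the scatter). Compound 3 gives the lowest number of the three, but its gaps to compound 1 and compound 2 are within the scatter, so no ranking can be read from this set.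

Compound 4 `O=C(O)CCc1ccc(NC(=O)c2nnc(Cc3ccc(Cl)cc3)s2)cc1` is not yet measured. The change from compound 3 is 4-chlorophenyl in place of 2-methylphenoxy on a saturated chain carbon bound to an aromatic carbon. Within the data shown here, none of the measured steps covers this change: each replaces one aryl ether by another aryl ether, whereas here the oxygen of the ether leaves with the aryl group and a 4-chlorophenyl enters directly on the saturated carbon. What the measured steps do show is that swapping substituents on the aryl group moves the number little. On that basis the expected step is a 1.3-fold higher number from compound 3 to compound 4 (0.12 log units; within the scatter), with the direction uncertain. The estimate for compound 4 in this assay is 2000 nM, with a range from 700 nM to 6000 nM.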

Compound 4, half-maximal effective concentration: 2390 nM
Compound 4: the middle estimate sits 1.2-fold (0.08 log units) below what was measured, within the range that was stated.
By their numbers in this assay, from the lowest: compounds 3, 1, 4 and 2 (each within the scatter of the next).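

In this assay, the ether oxygen can leave this saturated chain carbon bound to an aromatic carbon without a step beyond the scatter, whichever aryl ether is replaced (a 1.6-fold higher number from compound 3 to compound 4 (0.20 log units; within the scatter); a 1.6-fold higher number from compound 1 to compound 4 (0.19 log units; within the scatter); a 1.0-fold lower number from compound 2 to compound 4 (0.01 log units; within the scatter)). The loss of that oxygen and the entry of chlorine occur together in this change, so the shown compounds give no separate reading of either. No measurement at hand offers a cause for these small steps.

From the compounds shown here alone, whether any group at this place can move the number beyond the scatter remains open, as all four compounds lie within it of one another. An unsubstituted benzyl would separate the oxygen from the chlorine, while a cyclohexyl ring or an amine in place of the aryl group would test whether an aromatic ring is needed here.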